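The compounds below may be only part of what the source reports. "The series", "measured", "known", "first", "only" and "open" are said of these compounds alone.

Measured compounds:
compound 1, `Cc1ccnc(/C(N)=N/NC(=S)N2CCOCC2)c1`, gives 8.16% in a functional assay on MCF7 cells (Homo sapiens) for cytotoxicity, read by MTT assay, with a stated time of 72 h, tested at 30 uM; a higher number here means more inhibition of growth at the concentration tested, a lower number less inhibition of growth.
compound 2, `Cc1cccc(/C(N)=N/NC(=S)N2CCSCC2)n1`, gives 38.6% in this assay.
compound 3, `Cc1ccnc(/C(N)=N/NC(=S)N2CCSCC2)c1`, gives 74.2% in this assay.

The unmeasured compound 4, `Cc1cccc(/C(N)=N/NC(=S)N2CCOCC2)n1`, arises from compound 2 by morpholin-4-yl in place of thiomorpholin-4-yl on a thiocarbonyl carbon. The same change links two measured compounds: compound 3 becomes compound 1 by morpholin-4-yl in place of thiomorpholin-4-yl on a thiocarbonyl carbon, and in this assay that step is a number 66 percentage points lower from compound 3 to compound 1 (beyond the scatter). Compound 2 and compound 3 consist of the same atoms joined differently; the difference between the two cores is not broken down here. Compound 2 sits lower than compound 3 and higher than compound 1, both gaps beyond the scatter. The step from compound 2 to compound 4 is expected to be a number 32.6 percentage points lower from compound 2 to compound 4 (beyond the scatter), smaller than the earlier one because compound 2 starts at 38.6% and growth inhibition cannot fall far below nothing. Compound 4 is therefore estimated at 6%, within 0% to 25%.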

Compound 4, percent growth inhibition at one concentration: 57.8%
Compound 4: middle estimate off by 51.8 percentage points, on the low side, outside the stated range (above it).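

In this assay, morpholin-4-yl in place of thiomorpholin-4-yl on a thiocarbonyl carbon did not carry over from one core to the other, and the new step is a number 19.2 percentage points higher from compound 2 to compound 4 (beyond the scatter). The two steps run in opposite directions: the same change on two cores in this assay, a number 66 percentage points lower (beyond the scatter) from compound 3 to compound 1 and a number 19.2 percentage points higher (beyond the scatter) from compound 2 to compound 4, 85.2 percentage points apart, beyond the scatter of two such steps

This shows that, in these two pairs, the outcome of the change depends on the core, so a step read on one core could not be transferred to the other. For the compounds shown here, with only two pairs, it does not show what in the cores sets this difference, or how the change would behave on a further core.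

The compounds shown leave open how other groups on the thiocarbonyl carbon, such as a dimethylamino group or a longer-chain amine, would behave on either core.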